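The source may hold more compounds than are shown below. What is called first, only, known or untested is meant among the compounds shown, and "the series" means these compounds.

Measured in a functional assay on A2780 cells (Homo sapiens) for antiproliferative activity, read by MTT assay, with a stated time of 72 h (on this read-out lower numbers stand for stronger inhibition and higher numbers for weaker inhibition), so far:

compound 1 `CCNC(=O)NOCc1ccc(/C=C/C(=O)NO)cc1` gives 35400 nM
compound 2 `O=C(/C=C/c1ccc(CONC(=O)Nc2ccccc2)cc1)NO` gives 112000 nM
compound 3 `Cc1cc(C)cc(NC(=O)NOCc2ccc(/C=C/C(=O)NO)cc2)c1` gives 2010 nM

Compound 3 holds the lowest number of the three, with an 18-fold lower number from compound 1 to compound 3 (1.25 log units; beyond the scatter) and a 56-fold lower number from compound 2 to compound 3 (1.75 log units; beyond the scatter) showing how far it stands from the others. The next candidate is compound 4 `Cc1cc(C)c(NC(=O)NOCc2ccc(/C=C/C(=O)NO)cc2)c(C)c1`, which has 2,4,6-trimethylphenyl in place of 3,5-dimethylphenyl on an amide-type nitrogen. All three measured steps changed the group at this same place. Of these, a 3.2-fold higher number from compound 1 to compound 2 (0.50 log units; beyond the scatter) was modest, while the two that lead to compound 3 were large. The number has therefore moved in both directions with changes at this place, and none of the steps tests 2,4,6-trimethylphenyl. As far as these compounds go, the direction stays open, so no step beyond the scatter is the best guess, although a large step either way remains possible. In this assay the expected result is a 1.2-fold higher number from compound 3 to compound 4 (0.09 log units; within the scatter) and this estimate is uncertain. For compound 4 the estimate is 2500 nM with an expected range from 400 nM to 20000 nM as the likely span.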

Compound 4, half-maximal inhibitory concentration: 3390 nM
Compound 4: middle estimate off by 1.4-fold (0.13 log units), on the low side; the measured number falls inside the stated range.
By their numbers in this assay, from the lowest: compounds 3 and 4 (each within the scatter of the next); then compound 1; then compound 2.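

In this assay, 2,4,6-trimethylphenyl in place of 3,5-dimethylphenyl gives a 1.7-fold higher number from compound 3 to compound 4 (0.23 log units; within the scatter), so this assay does not separate these two methyl-bearing rings, even though their methyl groups are arranged differently and the count of ring carbons and methyls differs by one group. The new ring also stands well apart from the other two groups at this amide-type nitrogen, with a 33-fold lower number from compound 2 to compound 4 (1.52 log units; beyond the scatter) and a 10-fold lower number from compound 1 to compound 4 (1.02 log units; beyond the scatter), so the low numbers now hold for two methyl-bearing phenyl rings rather than for compound 3 alone. No measurement available here accounts for this pattern.

Still open, as far as these compounds go, is where a phenyl ring carrying a single methyl group would fall in this order. Open too, from the compounds shown here alone, is whether chlorine or methoxy on the ring could stand in for methyl.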